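The compounds below may be only part of what the source reports. "The series", "measured", "known", "first", "only" and "open" are said of these compounds alone.

Compound 1 `CCCc1cccc(C[C@H](O)/C=C/[C@H]2CSC(=O)N2CCSCCCC(=O)O)c1` was examined in an assay on CHO cells for displacement of a labelled ligand from prostaglandin E2 receptor EP2 subtype (Mus musculus), read by scintillation counting, with a stated time of 60 min; on this read-out higher numbers stand for weaker inhibition and lower numbers for stronger inhibition. In this assay compound 1 gives only a limit of the assay, > 10000 nM, and no number. Two other compounds have been measured in the same way. Compound 2 `CCCc1cccc(C[C@H](O)/C=C/[C@H]2CCC(=S)N2CCCCCCC(=O)O)c1` in this assay gives 6800 nM. Compound 3 `O=C(O)CCCSCCN1C(=O)OC[C@@H]1/C=C/[C@@H](O)Cc1cccc(C(F)(F)F)c1` in this assay gives a limit of the assay, > 10000 nM, rather than a number. Compound 1 therefore stands where most of the shown values stand, namely (the limit of > 10000 nM in this assay, at which 2 of the 3 values shown sit). Among the measured compounds shown here, no two of these three compounds differ in just one place, so no single structural step has yet been measured, and the spread of the numbers so far is narrow.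

Compound 4 `CCc1cccc(C[C@H](O)/C=C/[C@H]2CSC(=O)N2CCSCCCC(=O)O)c1` differs from compound 1 in one place only: hydrogen in place of methyl on a saturated chain carbon, two bonds along the chain from an aromatic carbon. The shared core and the acid-bearing side chain are kept unchanged. Because compound 1 gives > 10000 nM in this assay and so sits at the weak end of what this assay can report, there is little room for the number to rise further. A step that the limit leaves unreadable from compound 1 to compound 4 is expected, no larger than the usual scatter and in no settled direction. Compound 4 is thus estimated at 15000 nM, with a range from 5000 nM to 50000 nM, and the assay may well again report only a limit.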

Compound 4, inhibition constant: > 10000 nM
Compound 4 gave a limit, no number (the forecaster's own chance of this, stated with the estimate: 70%); the middle value is on the limit's open side.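

Compound 1 and compound 4 each give only a limit of the assay and no number, so the step between them cannot be read in this assay: the limit of > 10000 nM in this assay, at which 3 of the 4 values shown sit.

The compounds shown leave open whether going from 3-propylphenyl to 3-ethylphenyl changes the inhibition constant at all, and in which direction.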